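From 4-nitrophenyl to pyridin-4-yl on a shared core

The source may report more compounds than this note shows. Statements on the series, on what has been measured and on what is new or still open speak of the compounds shown alone.

In a functional assay on FM3A cells (Mus musculus) for antiproliferative activity (a higher number here means a weaker inhibitor, a lower number a stronger inhibitor), compound 1 (`COc1ccc(-c2cc(N)c(C(=O)c3cc(OC)c(OC)c(OC)c3)s2)cc1OC`) gives 72 nM, compound 2 (`COc1cc(C(=O)c2sc(-c3ccc([N+](=O)[O-])cc3)cc2N)cc(OC)c1OC`) gives 64 nM and compound 3 (`COc1cc(C(=O)c2sc(-c3cccc([N+](=O)[O-])c3)cc2N)cc(OC)c1OC`) gives 17 nM. Compound 2 therefore stands level with compound 1, and compound 3 has the lower number. Compound 4 (`COc1cc(C(=O)c2sc(-c3ccncc3)cc2N)cc(OC)c1OC`) carries pyridin-4-yl in place of 4-nitrophenyl on an aromatic carbon. Going by the values given here, no measured compound has this ring, so the only guide is the other swaps at this place. They give a 1.1-fold lower number from compound 1 to compound 2 (0.05 log units; within the scatter), a 4.2-fold lower number from compound 1 to compound 3 (0.63 log units; beyond the scatter) and a 3.8-fold lower number from compound 2 to compound 3 (0.58 log units; beyond the scatter). A modest rise in this assay is expected, though the data do not settle its direction. The expected step is a 2.3-fold higher number from compound 2 to compound 4 (0.37 log units; beyond the scatter). For compound 4 the estimate is 150 nM, with an expected range of 35 nM to 600 nM.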

Compound 4, half-maximal inhibitory concentration: 150 nM
Compound 4: middle estimate and measured number agree at the digits printed; the range from low to high includes it.
By their numbers in this assay, from the lowest: compound 3; then compounds 2 and 1 (each within the scatter of the next); then compound 4.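

In this assay, pyridin-4-yl differs from the other three rings at this position in having a ring nitrogen and no side group, and it gives the highest number of the four: a 2.3-fold higher number from compound 2 to compound 4 (0.37 log units; beyond the scatter), a 2.1-fold higher number from compound 1 to compound 4 (0.32 log units; beyond the scatter) and an 8.8-fold higher number from compound 3 to compound 4 (0.95 log units; beyond the scatter). The last of these is the largest step in the set, so the ring here can shift the number further than the two nitrophenyl groups alone showed. No measurement given here explains this step. The ring nitrogen and the missing nitro group change together, so their shares stay unseparated. As far as these compounds go, how plain phenyl or pyridin-3-yl would compare remains open.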